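The source may report more compounds than this note shows. Statements on the series, on what has been measured and on what is new or still open speak of the compounds shown alone.

Within the data shown here, in a physicochemical assay for solubility, measured as kinetic solubility, with a stated time of 1 h, at pH 7.4 (on this read-out lower numbers stand for lower solubility and higher numbers for higher solubility), compound 2 (`O=C(NC1=NN(c2ccc(Cl)c(Cl)c2)CC1)c1ccnnc1`) gives 23000 nM, the higher of the two numbers so far, while compound 1 (`O=C(NC1=NN(c2ccc(Cl)c(Cl)c2)CC1)c1ccncc1`) gives 9000 nM. Compound 3 (`O=C(NC1=NN(c2ccc(Cl)c(Cl)c2)CC1)c1cncnc1`) carries pyrimidin-5-yl in place of pyridazin-4-yl on a carbonyl carbon. Among the measured compounds shown here, the only measured step bearing on this swap is a 2.6-fold higher number from compound 1 to compound 2 (0.41 log units; beyond the scatter), modest and beyond the scatter, and it concerns a different ring change. With the counts unchanged, a slight fall within the scatter is expected in this assay. The expected step is a 1.4-fold lower number from compound 2 to compound 3 (0.16 log units; within the scatter). For compound 3 the estimated value is 16000 nM, with an expected range of 7000 nM to 35000 nM.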

Compound 3, solubility: 8000 nM
Compound 3: the middle estimate sits 2.0-fold (0.30 log units) above what was measured; the measured number falls inside the stated range.
By their numbers in this assay, from the lowest: compounds 3 and 1 (each within the scatter of the next); then compound 2.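

In this assay, pyrimidin-5-yl and pyridazin-4-yl on a carbonyl carbon have identical atom and hydrogen-bond counts, yet the numbers part beyond the scatter (a 2.9-fold lower number from compound 2 to compound 3 (0.46 log units; beyond the scatter)). Pyrimidin-5-yl and pyridin-4-yl stay within the scatter of each other (a 1.1-fold lower number from compound 1 to compound 3 (0.05 log units; within the scatter)), leaving compound 2 alone among the three, with steps beyond the scatter to both others. No measurement available here accounts for this difference.

From the compounds shown here alone, whether compound 2 keeps this separation on another core remains open. Also open, going by these compounds, is how a carboxylic acid or an amine on the aromatic ring would read at this position.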